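Removing a Methoxy Group from an Indanone Aromatase Inhibitor

The source may report more compounds than this note shows. Statements on the series, on what has been measured and on what is new or still open speak of the compounds shown alone.

In an assay on isolated protein for inhibition of Aromatase (Homo sapiens), read by scintillation counting (a lower number here means a stronger inhibitor, a higher number a weaker inhibitor), compound 2 `COc1ccc(/C=C2\Cc3ccccc3C2=O)cc1OCCCn1ccnc1` gives 1340 nM, the highest of the three numbers recorded. Compound 1 `O=C1/C(=C/c2ccccc2OCCCn2ccnc2)Cc2ccccc21` gives 1100 nM, within the scatter of compound 2, while compound 3 `COc1cc(/C=C2\Cc3ccccc3C2=O)ccc1OCCCn1ccnc1` gives 550 nM. The number for compound 3 is lower than that of compound 2, with a gap that lies beyond the scatter. Compound 4 `O=C1/C(=C/c2cccc(OCCCn3ccnc3)c2)Cc2ccccc21` has not yet been measured in this assay. It differs from compound 2 in one place: hydrogen in place of methoxy on an aromatic carbon, ortho to a 3-(1H-imidazol-1-yl)propoxy group and para to a large group. Going by the values given here, no pair of measured compounds shows this change on its own. Compound 1 also carries no methoxy group and gives 1100 nM, within the scatter of compound 2. A small step is therefore expected, a 1.4-fold lower number from compound 2 to compound 4 (0.15 log units; within the scatter), with no direction beyond the scatter. Compound 4 is estimated at 950 nM, ranging from 400 nM to 2200 nM.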

Compound 4, half-maximal inhibitory concentration: 700 nM
The estimate for compound 4 lay 1.4-fold (0.13 log units) above the measured number; the range from low to high includes it.
By their numbers in this assay, from the lowest: compounds 3, 4, 1 and 2 (each within the scatter of the next, the first and the last beyond it).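

On an aromatic carbon ortho to a 3-(1H-imidazol-1-yl)propoxy group and para to a large group, hydrogen in place of methoxy gives a step within the scatter in this assay (a 1.9-fold lower number from compound 2 to compound 4 (0.28 log units; within the scatter)). This single change therefore shows that the methoxy group at this position can give way to hydrogen without a difference that this assay can separate from the scatter. No supporting evidence bears on this step. The compounds shown leave open whether a hydroxyl group or a fluorine atom on this same carbon would move the number beyond the scatter.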